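Inverting One Ring Stereocentre in a Rat Exposure Series

The source may report more compounds than this note shows. Statements on the series, on what has been measured and on what is new or still open speak of the compounds shown alone.

Measured compounds:
compound 1 `COCCNc1cc(NC(=O)N2CCCc3cc(CN4CC[C@H](OC)C4=O)c(C=O)nc32)ncc1C#N`: 11300 ng.h/mL
compound 2 `CO[C@H]1CCN(c2cc(NC(=O)N3CCCc4cc(CN5CCOCC5=O)c(C=O)nc43)ncc2C#N)C1`: 14700 ng.h/mL

Two compounds have so far been run in an ADME assay on the whole organism (Rattus norvegicus, strain Sprague-Dawley) for pharmacokinetics, read by LC-MS, with stated times of 5 min and 24 h, at a dose of 5 mg/kg by the oral route; a lower number here means less compound in the circulation, a higher number more compound in the circulation at the dose given. In this assay compound 1 gives 11300 ng.h/mL, and compound 2 gives 14700 ng.h/mL. These two numbers lie within the scatter of each other, so neither compound can be said to give more or less exposure than the other on the evidence at hand. Compound 1 has the lower of the two figures, but the gap to compound 2 is no more than repeat measurements would show.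

Compound 3 `COCCNc1cc(NC(=O)N2CCCc3cc(CN4CC[C@@H](OC)C4=O)c(C=O)nc32)ncc1C#N` is the next compound to be measured in this assay. It differs from compound 1 only in configuration, as follows: the two compounds have the same atoms and bonds and differ only in configuration as drawn: 1 of 1 stereo elements differ; a stereocentre at a saturated ring carbon is drawn S in compound 1 and R in compound 3.

For the measured compounds named here, no step between measured compounds is available to calibrate what such a change does here. The expectation therefore rests on compound 1 alone, and on the observation that compound 1 and compound 2 sit close together. Compound 3 is expected to show a 1.0-fold lower number from compound 1 to compound 3 (0.01 log units; within the scatter). For compound 3 the estimate in this assay is 11000 ng.h/mL, with a range from 5000 ng.h/mL to 24000 ng.h/mL.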

Compound 3, area under the concentration-time curve: 12300 ng.h/mL
Compound 3: middle estimate off by 1.1-fold (0.05 log units), on the low side; the measured number falls inside the stated range.
By their numbers in this assay, from the lowest: compounds 1, 3 and 2 (each within the scatter of the next).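

In this assay the step is a 1.1-fold higher number from compound 1 to compound 3 (0.04 log units; within the scatter), so at this saturated ring carbon the S and R drawings cannot be told apart by oral exposure in the rat. For the compounds shown here, the earlier compounds could not show this: they differ in more than one place and offered no reading of this stereocentre on its own, whereas this pair gives the first direct reading of what inversion at this position does, and that reading is of no difference beyond repeat measurement. The step can be assigned to this single change alone, with no other structural difference to confound it, since the evidence is: the fact that compounds 1 and 3 differ only in the configuration as drawn.

The compounds shown leave open whether a different group at this ring carbon, such as an ethoxy group, a hydroxyl group or an amine in place of the methoxy group, would move the exposure beyond the scatter in either configuration. They also leave open whether inverting the stereocentre that compound 2 carries on its own saturated ring would prove just as silent in this assay.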